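Switching the aryl ketone from methylphenyl to fluorophenyl

The compounds below may be only part of what the source reports. "The series", "measured", "known", "first", "only" and "open" are said of these compounds alone.

Of the compounds shown here, three sharing one core have been measured in a functional assay on MCF7 cells (Homo sapiens) for cytotoxicity, read by MTT assay, with a stated time of 48 h; a higher number here means a weaker inhibitor, a lower number a stronger inhibitor. Compound 1 `COc1cc(-c2nnc3n2NC(c2ccco2)C(C(=O)c2ccc(F)c(F)c2)S3)cc(OC)c1OC` gives 73200 nM. Compound 2 `COc1cc(-c2nnc3n2NC(c2ccco2)C(C(=O)c2ccc(-c4ccccc4)cc2)S3)cc(OC)c1OC` reaches only the limit of the assay, > 100000 nM, which is a limit rather than a number. Compound 3 `COc1cc(-c2nnc3n2NC(c2ccco2)C(C(=O)c2ccccc2C)S3)cc(OC)c1OC` gives 69900 nM. On these numbers compound 3 and compound 1 lie within the scatter of each other, and the third value is a limit, so no one of the three can be called weaker or stronger than the rest. Compound 4 `COc1cc(-c2nnc3n2NC(c2ccco2)C(C(=O)c2ccc(F)cc2)S3)cc(OC)c1OC` has not yet been measured. Its difference from compound 3 is 4-fluorophenyl in place of 2-methylphenyl on a carbonyl carbon.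

The step that bears most on this change is a 1.0-fold lower number from compound 1 to compound 3 (0.02 log units; within the scatter), where 3,4-difluorophenyl gave way to 2-methylphenyl without any shift beyond the scatter. The steps of an at least 1.3-fold higher number from compound 1 to compound 2 (0.13 log units; that floor lies within the scatter) and an at least 1.4-fold lower number from compound 2 to compound 3 (0.15 log units; that floor lies within the scatter) only set floors, because compound 2 sits at the limit of > 100000 nM in this assay, at which 1 of the 3 values shown sits. Returning from 2-methylphenyl to a fluorine-bearing phenyl, here 4-fluorophenyl, is therefore expected to leave the number about where compound 3 stands, and the expected step is a 1.0-fold higher number from compound 3 to compound 4 (0.01 log units; within the scatter). Compound 4 is accordingly estimated at 72000 nM, with a range from 36000 nM to 144000 nM.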

Compound 4, half-maximal inhibitory concentration: > 100000 nM
Compound 4: a limit, no number; the forecaster's own chance of this, stated with the estimate: 20%; middle value at least 1.3-fold (0.14 log units) from the limit.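

In this assay compound 4 stands at a limit and not at a number, and it is the second compound to do so: the limit of > 100000 nM in this assay, at which 2 of the 4 values shown sit. Until now only 4-phenylphenyl on the carbonyl carbon had reached that limit, whereas 4-fluorophenyl has as many heavy atoms as 2-methylphenyl, which shows that keeping that count does not by itself keep a readable number at this place. Going by these compounds, the two readable steps, an at least 1.4-fold higher number from compound 3 to compound 4 (0.15 log units; that floor lies within the scatter) and an at least 1.3-fold higher number from compound 1 to compound 4 (0.13 log units; that floor lies within the scatter), are only floors, so the true size of either change remains unknown, and the step between compound 2 and compound 4 cannot be read at all.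

The compounds shown leave open how far past the limit compound 2 and compound 4 really lie, and so whether swapping 2-methylphenyl for 4-fluorophenyl matters much or hardly at all. They also leave open what a phenyl ring carrying an amine or a carboxylic acid would do on this carbonyl carbon, and whether either would give a readable number.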